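A few compounds are considered here, and "the series" means these few. Any claim that something is new, unique, unknown or untested is made for them only; others in the source may bear on it.

Going by the values given here, in a functional assay on B16-F10 cells (Mus musculus) for cytotoxicity (on this read-out higher numbers stand for weaker inhibition and lower numbers for stronger inhibition), three compounds with a shared core have numbers so far. Compound 1 (`O=c1oc2ccccc2c2nc3c(ccc4cc[nH]c43)c(-c3ccc(Br)cc3)c12`) gives 70700 nM, compound 2 (`O=c1oc2ccccc2c2nc3c(ccc4cc[nH]c43)c(-c3ccccn3)c12`) gives 70700 nM and compound 3 (`O=c1oc2ccccc2c2nc3c(ccc4cc[nH]c43)c(-c3ccc(Cl)cc3Cl)c12`) gives 70700 nM, so compound 3 stands level with the other two.

The next compound, compound 4 (`O=c1oc2ccccc2c2nc3c(ccc4cc[nH]c43)c(-c3ccc(F)cc3)c12`), differs from compound 3 by one swap: 4-fluorophenyl in place of 2,4-dichlorophenyl on an aromatic carbon.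

Three measured swaps on that same aromatic carbon bear on this one. Replacing 4-bromophenyl with pyridin-2-yl gave no change at the digits printed from compound 1 to compound 2 (within the scatter) and replacing it with 2,4-dichlorophenyl gave no change at the digits printed from compound 1 to compound 3 (within the scatter), while the remaining pair showed no change at the digits printed from compound 2 to compound 3 (within the scatter) as well. Among the compounds with values here, none of these steps moved the value, although no 4-fluorophenyl compound has been measured yet.

No step beyond the scatter is therefore expected, and no direction is favoured: the estimated step is no change at the digits printed from compound 3 to compound 4 (within the scatter). For compound 4 the estimated value is 70700 nM, with an expected range from 35000 nM to 100000 nM.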

Compound 4, half-maximal inhibitory concentration: 70700 nM
For compound 4 middle estimate and measured number coincide at the digits printed; measured number inside the range.
By their numbers in this assay, from the lowest: compounds 1, 2, 3 and 4 (each within the scatter of the next).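

In this assay the 4-fluorophenyl group joins the others on this aromatic carbon, opposite the ring nitrogen: in place of 2,4-dichlorophenyl it gave no change at the digits printed from compound 3 to compound 4 (within the scatter) and in place of pyridin-2-yl it gave no change at the digits printed from compound 2 to compound 4 (within the scatter) as well. Fluoro in place of bromo gave no change at the digits printed from compound 1 to compound 4 (within the scatter) too, so an exchange of a single halogen now stands beside the exchanges of whole rings, and four different groups here share one value. Nothing measured here explains why these numbers stay level.

On these data alone, all four groups are six-membered aromatic rings, so it remains open whether an amine, a carboxylic acid or a longer alkyl chain on this carbon would move the number. As far as these compounds go, it is also open whether a change elsewhere on the shared core would do so.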